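Amide nitrogen substituents: from cyclopentyl to 2-hydroxyethyl

This account rests on a few compounds, and the source may have more. Where it says the series, first, only, none or still open, it means among the compounds named here.

Measured so far:
compound 1 `CCCNC(=O)CC1CCc2cc(OC)c(OC)cc21`: compound 1 gives 26.6% in a functional assay on the whole organism (strain Wistar) for inhibition, with Rattus norvegicus as the target, read by paw edema, with stated times of 60 min and 4 h, at a dose of 100 mg/kg by the oral route; a lower number here means less inhibition, a higher number more inhibition at the dose given (going by the name of the read-out)
compound 2 `COc1cc2c(cc1OC)C(CC(=O)NC1CCCC1)CC2`: compound 2 gives 45.3% in this assay

Among the compounds with values here, compound 2 holds the higher of the two numbers so far in this assay; the only measured step is a number 18.7 percentage points higher from compound 1 to compound 2 (beyond the scatter), a modest rise beyond the scatter. Compound 3 `COc1cc2c(cc1OC)C(CC(=O)NCCO)CC2` has not yet been measured in this assay. It differs from compound 2 at the amide nitrogen: 2-hydroxyethyl in place of cyclopentyl on an amide-type nitrogen. Within the data shown here, the one measured step bears on this only indirectly, since it also changes the group on that nitrogen but in another direction, and no measured compound carries a 2-hydroxyethyl there. Because a number 18.7 percentage points higher from compound 1 to compound 2 (beyond the scatter) shows that changing this group moves the read-out beyond the scatter, a step in this assay is expected here as well, most likely downward, a number 17.3 percentage points lower from compound 2 to compound 3 (beyond the scatter), with wide uncertainty. Compound 3 is estimated at 28%, with a range from 10% to 48%.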

Compound 3, a percentage reported as inhibition, in the whole organism at one dose (the size of the read-out at that dose, not a potency): 9.37%
The estimate for compound 3 lay 18.6 percentage points above the measured number, outside the stated range (below it).
By their numbers in this assay, from the lowest: compound 3; then compound 1; then compound 2.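

In this assay, within the data shown here, this position moves the read-out down as well as up: the only earlier step was a rise, while 2-hydroxyethyl in place of cyclopentyl on the amide-type nitrogen gives a number 35.9 percentage points lower from compound 2 to compound 3 (beyond the scatter). The fall does not rest on losing the ring alone, since hydroxy in place of methyl on the open chain gives a number 17.2 percentage points lower from compound 1 to compound 3 (beyond the scatter), so a single change on the propyl chain of compound 1 is also enough to lower the number. No measurement at hand gives a reason for either step.

From the compounds shown here alone, whether an amine or a carboxylic acid in place of the hydroxy would lower the number in the same way remains open, as does the effect of a longer chain carrying the hydroxy. Also open, going by these compounds, is whether cyclohexyl on the same nitrogen would match or pass compound 2.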